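The compounds below may be only part of what the source reports. "The series", "measured", "known", "first", "only" and "open" are said of these compounds alone.

Measured so far:
Compound 1, `O=C(c1ccccc1)c1sc(N2CCN(c3ccccc3)CC2)nc1-c1ccc([N+](=O)[O-])cc1`: in an assay for inhibition of Polyunsaturated fatty acid 5-lipoxygenase (Homo sapiens), read by spectrophotometry, tested at 10 uM (a higher number here means more inhibition at the concentration tested (going by the name of the read-out), a lower number less inhibition), compound 1 gives 67.8%.
Compound 2, `O=C(NC(=S)N1CCCCC1)c1ccccc1`: in this assay compound 2 gives 56.8%.

Of the two numbers at hand, compound 2 stands at the lower one. Its nearest neighbour is compound 1, which lies higher by a gap larger than the usual scatter of repeated measurements, so the two compounds are genuinely apart. Compound 1 and compound 2 share no common change in a single place, so no single-step comparison between measured compounds is available to lean on.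

The next compound, compound 3, `O=C(NC(=S)N1CCCCC1)c1ccc(F)cc1`, has not yet been measured. It differs from compound 2 in exactly one place: fluoro in place of hydrogen on an aromatic carbon. This is a very small change, a single fluorine atom taking the place of a hydrogen on the aromatic ring at the far end from the rest of the molecule.

With nothing measured to show how such a swap plays out here, the expectation is for a step of no size beyond the scatter in this assay, neither clearly up nor clearly down. The expected step of a number 1.2 percentage points higher from compound 2 to compound 3 (within the scatter) is therefore estimated to be small. Compound 3 is expected to give about 58%, with a likely range from 42% to 74%.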

Compound 3, a percentage reported as inhibition, at one concentration (the size of the read-out at that concentration, not a potency): 80.7%
The estimate for compound 3 lay 22.7 percentage points below the measured number; the whole stated range lies below it.
By their numbers in this assay, from the lowest: compound 2; then compound 1; then compound 3.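

In this assay, a single fluoro in place of hydrogen on an aromatic carbon, para to a large group, gives a step of a number 23.9 percentage points higher from compound 2 to compound 3 (beyond the scatter), so this position on the six-membered aromatic ring is not indifferent to change. Within the data shown here, the earlier compounds offered no single-place comparison, and this pair is the first to show that adding only one heavy atom, with no ring, hydrogen-bond donor, hydrogen-bond acceptor or net charge, can shift inhibition at the tested concentration by more than the usual scatter. Nothing measured here explains why this small swap has such an effect.

This single step cannot show whether the gain is specific to fluoro or would also appear with a chloro group, a methoxy group or an amine on the same aromatic carbon. It also leaves open whether fluoro at other places on that ring, or the same swap on the core of compound 1 , would produce a step of similar size and direction.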